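Fluoro for methoxy on the anilino ring of the core

The source may report more compounds than this note shows. Statements on the series, on what has been measured and on what is new or still open speak of the compounds shown alone.

The shared core carries an amino-linked aryl group that varies across the set. In a functional assay on PC-3 cells (Homo sapiens) for cytotoxicity, read by MTT assay, with a stated time of 72 h (a higher number here means a weaker inhibitor, a lower number a stronger inhibitor), compound 1 `COc1ccc(Nc2cc(C)nc(SCc3nc4ccccc4[nH]3)n2)cc1` gives 67400 nM, the higher of the two numbers in hand. Compound 3 `Cc1ccc(Nc2cc(C)nc(SCc3nc4ccccc4[nH]3)n2)cc1` gives 56000 nM, and the step of a 1.2-fold lower number from compound 1 to compound 3 (0.08 log units; within the scatter) sits within the scatter. For compound 2 `Cc1cc(NNC(N)=S)nc(SCc2nc3ccccc3[nH]2)n1` this assay reports only a limit, > 100000 nM. The step of an at least 1.4-fold higher number from compound 1 to compound 2 (0.17 log units; that floor lies within the scatter) and the step of an at least 1.7-fold lower number from compound 2 to compound 3 (0.25 log units; that floor lies within the scatter) both rest on that limit of > 100000 nM in this assay, at which 1 of the 3 values shown sits, and so give floors only, not sizes.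

Compound 4 `Cc1cc(Nc2ccc(F)cc2)nc(SCc2nc3ccccc3[nH]2)n1` has not yet been measured. It differs from compound 1 by fluoro in place of methoxy on an aromatic carbon. Within the data shown here, the one measured change at the same place, a 1.2-fold lower number from compound 1 to compound 3 (0.08 log units; within the scatter), stayed within the scatter, so no step beyond the scatter is expected from this exchange either. The estimate for compound 4 in this assay is 60000 nM, between 30000 nM and 120000 nM, which is expected to be a step of a 1.1-fold lower number from compound 1 to compound 4 (0.05 log units; within the scatter) and to remain within the scatter.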

Compound 4, half-maximal inhibitory concentration: 56200 nM
Estimate against measurement, compound 4: 1.1-fold (0.03 log units) above; measured number inside the range.
By their numbers in this assay, from the lowest: compounds 3, 4 and 1 (each within the scatter of the next). At a limit, above all of these: compound 2.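

In this assay, fluoro in place of methoxy gives a 1.2-fold lower number from compound 1 to compound 4 (0.08 log units; within the scatter), and fluoro in place of methyl gives a 1.0-fold higher number from compound 3 to compound 4 (0.00 log units; within the scatter). Methoxy, methyl and fluoro, para to a large group, therefore stand within the scatter of one another across compounds 1, 3 and 4, so this position now shows a second exchange, and the first direct comparison of two replacements for methoxy, without a step beyond the scatter. The step of an at least 1.7-fold lower number from compound 2 to compound 4 (0.25 log units; that floor lies within the scatter) gives a floor only and cannot be read as a size, as it rests on a limit: the limit of > 100000 nM in this assay, at which 1 of the 4 values shown sits.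

On these data alone, it remains open whether an amine or a carboxylic acid at this place would give a step beyond the scatter. Also open, as far as these compounds go, is whether these exchanges would read the same way on a core altered elsewhere.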